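Swapping the amide partner at the carbonyl carbon

A few compounds are considered here, and "the series" means these few. Any claim that something is new, unique, unknown or untested is made for them only; others in the source may bear on it.

Compound 1 `O=C(N1CCC(c2nc(-c3ccc4ccccc4n3)no2)CC1)N1CCCc2ccccc21` gives 2300 nM in a functional assay on Shh Light II cells (Mus musculus) for inhibition, read by a luciferase reporter (a higher number here means a weaker inhibitor, a lower number a stronger inhibitor), one of two numbers that sit within the scatter of each other. Compound 2 `O=C(NC1CCC(O)CC1)N1CCC(c2nc(-c3ccc4ccccc4n3)no2)CC1` gives 2700 nM in this assay, and the step of a 1.2-fold higher number from compound 1 to compound 2 (0.07 log units; within the scatter) shows that exchanging the group on the carbonyl carbon stayed within the scatter. Compound 3 `COc1ccccc1OC(=O)N1CCC(c2nc(-c3ccc4ccccc4n3)no2)CC1` carries a different exchange at the same place: 2-methoxyphenoxy in place of 1,2,3,4-tetrahydroquinolin-1-yl on a carbonyl carbon. Among the compounds with values here, only that one measured step bears on it, and it was within the scatter, so the expected step of a 1.1-fold higher number from compound 1 to compound 3 (0.04 log units; within the scatter) is small in either direction. Compound 3 is therefore estimated at 2500 nM, with a range from 900 nM to 7000 nM.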

Compound 3, half-maximal inhibitory concentration: 250 nM
Beside the measured number, compound 3's estimate is 10-fold (1.00 log units) above it, and the stated range ends above it.
By their numbers in this assay, from the lowest: compound 3; then compounds 1 and 2 (each within the scatter of the next).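

The carbonyl carbon is not a place where every exchange leaves the number unchanged: 2-methoxyphenoxy gives a 9.2-fold lower number from compound 1 to compound 3 (0.96 log units; beyond the scatter) and an 11-fold lower number from compound 2 to compound 3 (1.03 log units; beyond the scatter) in this assay, whereas the two nitrogen-linked groups sit within the scatter of each other. Compound 3 alone joins its group to the carbonyl carbon through oxygen, so the effects of that oxygen and of the methoxy-bearing ring cannot be separated. Nothing measured here explains the drop. Still open, from the compounds shown here alone, is whether plain phenoxy, without the methoxy, or 2-methoxyanilino, with nitrogen as the link, would keep the lower number.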